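This account rests on a few compounds, and the source may have more. Where it says the series, first, only, none or still open, it means among the compounds named here.

Compound 2, `Cc1ccccc1C(=O)OC1(C(=O)Nc2ccc([N+](=O)[O-])cc2)CCCCC1`, gives 352 nM in an ADME assay on WI-38 cells (Homo sapiens) for inhibition, read by MTT assay, with a stated time of 72 h; a higher number here means a weaker inhibitor, a lower number a stronger inhibitor. Among the three compounds that share its core it stands second highest: compound 3, `CCOC(=O)c1ccccc1C(=O)OC1(C(=O)Nc2ccc([N+](=O)[O-])cc2)CCCCC1`, gives 386 nM in this assay, and compound 1, `Cc1ccc(C(=O)OC2(C(=O)Nc3ccc([N+](=O)[O-])cc3)CCCCC2)cc1`, gives 32 nM. The step from compound 1 to compound 2 is an 11-fold higher number from compound 1 to compound 2 (1.04 log units; beyond the scatter); the step from compound 2 to compound 3 is a 1.1-fold higher number from compound 2 to compound 3 (0.04 log units; within the scatter).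

Compound 4, `O=C(/C=C/c1ccccc1)OC1(C(=O)Nc2ccc([N+](=O)[O-])cc2)CCCCC1`, is related to compound 2 by one change: 2-phenylethenyl in place of 2-methylphenyl on a carbonyl carbon. Neither measured step is a close match. The step of an 11-fold higher number from compound 1 to compound 2 (1.04 log units; beyond the scatter) shows that moving the methyl from one aromatic position to another carries a large shift, while the step of a 1.1-fold higher number from compound 2 to compound 3 (0.04 log units; within the scatter) shows that exchanging the group at the second position of the phenyl leaves the number where it was. Among the measured compounds shown here, compound 4 loses that aromatic substituent altogether and gains a double bond outside the ring, a change with no measured counterpart here. The expectation is therefore uncertain, leaning toward a moderately lower number: compound 4 is estimated at 150 nM, with a range from 40 nM to 600 nM, which means an expected step of a 2.3-fold lower number from compound 2 to compound 4 (0.37 log units; beyond the scatter).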

Compound 4, half-maximal inhibitory concentration: 41 nM
The estimate for compound 4 lay 3.7-fold (0.56 log units) above the measured number; the range from low to high includes it.
By their numbers in this assay, from the lowest: compounds 1 and 4 (each within the scatter of the next); then compounds 2 and 3 (each within the scatter of the next).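

In this assay, putting 2-phenylethenyl in place of 2-methylphenyl on this carbonyl carbon gives an 8.6-fold lower number from compound 2 to compound 4 (0.93 log units; beyond the scatter), so the number at this position can fall a long way without any substituent on the phenyl ring and without the 4-methylphenyl group of compound 1. Among the compounds shown here, the step of a 1.3-fold higher number from compound 1 to compound 4 (0.11 log units; within the scatter) sets 2-phenylethenyl level with 4-methylphenyl, which means that two quite different groups on this carbonyl carbon now reach the same low range, whereas the earlier compounds tied that range to a single placing of the methyl. No measurement of any property of these groups is available to account for this, so the result stands as a description and not as an explanation.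

The compounds shown leave open whether the double bond of 2-phenylethenyl matters at all, a question that a saturated 2-phenylethyl chain on the same carbonyl carbon would address directly. Going by these compounds, it also remains open how far this position tolerates other groups, such as a 4-aminophenyl or a 4-carboxyphenyl group in place of 4-methylphenyl.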